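This account rests on a few compounds, and the source may have more. Where it says the series, first, only, none or still open, it means among the compounds named here.

Compound 1 (`COc1cc(-c2ncnn2-c2ccc(Cl)cc2Cl)cc(OC)c1OC`) gives > 10000 nM in a functional assay on HL-60 cells (Homo sapiens) for antiproliferative activity, read by MTT assay, with a stated time of 72 h (on this read-out lower numbers stand for stronger inhibition and higher numbers for weaker inhibition), as a limit of the assay and not a number. In this assay, going by the values given here, compound 2 (`COc1ccc(-c2ncnn2-c2cc(OC)c(OC)c(OC)c2)cc1`) gives 120 nM as the only actual number so far. Compound 3 (`COc1cc(-n2ncnc2-c2ccccc2)cc(OC)c1OC`) follows from compound 2 through hydrogen in place of methoxy on an aromatic carbon with hydrogen in place of methoxy on an aromatic carbon, 4-methoxyphenyl to phenyl. Among the compounds with values here, no measured step covers this change. The estimated step of a 13-fold higher number from compound 2 to compound 3 (1.10 log units; beyond the scatter) is expected to be a clear weakening beyond the scatter in this assay and not a gain. Compound 3 is estimated at 1500 nM with an expected range of 200 nM to 10000 nM in this measurement.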

Compound 3, half-maximal inhibitory concentration: > 10000 nM
Compound 3: only a limit was reported; the forecaster's own chance of this, stated with the estimate: 25%; at least 6.6-fold (0.82 log units) between middle value and limit.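

In this assay, going by these compounds alone, going from 4-methoxyphenyl to phenyl gives an at least 83-fold higher number from compound 2 to compound 3 (1.92 log units; beyond the scatter), the first single change that can be read in this set. It shows that the methoxy para to a large group cannot be replaced by hydrogen without a large loss. Compound 3 gives only a limit and not a number, so the step's full size stays unknown: the limit of > 10000 nM in this assay, at which 2 of the 3 values shown sit.

From the compounds shown here alone, whether a hydroxyl, an ethoxy or a chlorine in this place would keep the value near that of compound 2 stays open. So does the role of the three methoxy groups on the other ring.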